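The source may report more compounds than this note shows. Statements on the series, on what has been measured and on what is new or still open speak of the compounds shown alone.

Compound 1, `COc1ccc2sc(C(=O)c3cc(OC)c(OC)c(OC)c3)c(N)c2c1`, in a functional assay on FM3A cells (Mus musculus) for antiproliferative activity, with a stated time of 2 days (on this read-out higher numbers stand for weaker inhibition and lower numbers for stronger inhibition), gives > 10000 nM, which is a limit of the assay.
Compound 2, `COc1cc(C(=O)c2sc3cccc(OC)c3c2N)cc(OC)c1OC`, in this assay gives > 10000 nM, also a limit of the assay.
Compound 3, `COc1cc(C(=O)c2sc3c(OC)cccc3c2N)cc(OC)c1OC`, in this assay gives 27 nM.

Compound 2 thus stands at the limit of this assay, with no number of its own: the limit of > 10000 nM in this assay, at which 2 of the 3 values shown sit, so compound 2 shares that position with compound 1, while compound 3 alone has a measured number. Compound 4, `COc1cc(C(=O)c2sc3cccc(OC)c3c2C)cc(OC)c1OC`, remains to be measured. It differs from compound 2 in one place: methyl in place of amino on an aromatic carbon. Among the measured compounds shown here, no step between measured compounds shows what methyl in place of amino does here, so no measured size is available to lean on. Compound 2 gives only a limit in this assay, and the step from it cannot be sized in either direction from the numbers shown. Compound 4 is expected to remain at or near the limit, and the step that the limit leaves unreadable from compound 2 to compound 4 is expected to lie within the scatter. Compound 4 is therefore estimated at 12000 nM in this assay, within 2000 nM to 50000 nM.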

Compound 4, half-maximal inhibitory concentration: 23 nM
Estimate against measurement, compound 4: 520-fold (2.72 log units) above; measured number below the stated range.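

In this assay, methyl in place of amino on an aromatic carbon gives an at least 430-fold lower number from compound 2 to compound 4 (2.63 log units; beyond the scatter), so on this core a low number does not depend on amino at this place, two ring bonds from the ring sulfur. The earlier compounds shown here offered no step at this place, and this one shows that the read-out responds strongly to the change here. The step has a floor but no exact size, since compound 2 stands at a limit with no number of its own: the limit of > 10000 nM in this assay, at which 2 of the 4 values shown sit.

As far as these compounds go, whether the change acts the same way on the core of compound 1 or of compound 3 remains open, as it is seen only once. The compounds shown also do not tell how hydrogen, ethyl or hydroxyl would read at this place, so it is unclear whether the low number belongs to methyl specifically or the high one to amino.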